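The source may report more compounds than this note shows. Statements on the series, on what has been measured and on what is new or still open speak of the compounds shown alone.

Measured so far in a functional assay on WM 266-4 cells (Homo sapiens) for antiproliferative activity, read by MTT assay, with a stated time of 24 h; a higher number here means a weaker inhibitor of growth, a lower number a stronger inhibitor of growth:
compound 1, `COc1ccc(C2=NN(C(=O)c3cccnc3Cl)C(c3ccc(Cl)cc3)C2)cc1`, gives 780 nM.
compound 2, `COc1ccc(C2=NN(C(=O)c3ccc(C)nc3)C(c3ccc(Cl)cc3)C2)cc1`, gives 890 nM.
compound 3, `O=C(c1cccnc1Cl)N1N=C(c2ccc(Cl)cc2)CC1c1ccc(OCc2ccccc2)cc1`, gives 7710 nM.

The change from compound 1 to compound 2 is 6-methylpyridin-3-yl in place of 2-chloropyridin-3-yl on a carbonyl carbon. It made a 1.1-fold higher number from compound 1 to compound 2 (0.06 log units; within the scatter). The difference between the core of compound 1 and the core of compound 3 is not broken down here; what the two values show is that compound 3 carries the highest number of the three, beyond the scatter from compound 1 and from compound 2 alike.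

Compound 4, `Cc1ccc(C(=O)N2N=C(c3ccc(Cl)cc3)CC2c2ccc(OCc3ccccc3)cc2)cn1`, is not yet measured. It differs from compound 3 by 6-methylpyridin-3-yl in place of 2-chloropyridin-3-yl on a carbonyl carbon, the same change at the same place as that from compound 1 to compound 2, so it is counted as the same change, seen twice in all among these compounds. In this assay the step from compound 3 to compound 4 is expected to be a 1.1-fold higher number from compound 3 to compound 4 (0.04 log units; within the scatter), a step set beside the earlier one, because that earlier step gave a 1.1-fold higher number from compound 1 to compound 2 (0.06 log units; within the scatter). The expectation rests on a single measured pair, carried onto a core whose difference from the first core is not broken down, so the range is kept wide. For compound 4 the estimate is 8500 nM, expected to fall between 3800 nM and 19000 nM.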

Compound 4, concentration for 50% growth inhibition: 9200 nM
Compound 4: middle estimate off by 1.1-fold (0.03 log units), on the low side; the range from low to high includes it.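

In this assay, 6-methylpyridin-3-yl in place of 2-chloropyridin-3-yl on the carbonyl carbon gives a 1.2-fold higher number from compound 3 to compound 4 (0.08 log units; within the scatter) and the same exchange on the other core reads alike: the same change on two cores in this assay, a 1.1-fold higher number (0.06 log units; within the scatter) from compound 1 to compound 2 and a 1.2-fold higher number (0.08 log units; within the scatter) from compound 3 to compound 4, 1.0-fold (0.02 log units) apart, within the scatter of two such steps

On these two cores, then, the exchange carries over as a step within the scatter, and the two steps cannot be told apart. This does not show that the two groups are interchangeable in general: a step within the scatter cannot separate a small real effect from none, and two pairs say nothing about any further core.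

The compounds shown leave open whether a group of another kind on the carbonyl carbon, such as a morpholine amide or a phenyl ring bearing a carboxylic acid, would move the number beyond the scatter. Also open, going by these compounds, is whether the methyl group or the chlorine could be replaced on the pyridine ring by a longer chain without a step of that size.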